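Pyrazin-2-yl gives way to 1-methylpiperidin-4-yl on the carbonyl

This account rests on a few compounds, and the source may have more. Where it says the series, first, only, none or still open, it means among the compounds named here.

Measured in a functional assay on KBVIN cells (Homo sapiens) for antiproliferative activity, read by sulforhodamine B assay, with a stated time of 3 days; on this read-out higher numbers stand for weaker inhibition of growth and lower numbers for stronger inhibition of growth:
Compound 1 `O=C(Nc1ccc(C(F)(F)F)cc1)c1cccc(Nc2ncc(F)c(Nc3ccc(F)cc3)n2)c1`: > 10000 nM (a limit)
Compound 2 `COc1ccc(NC(=O)c2cccc(Nc3ncc(F)c(Nc4ccc(F)cc4)n3)c2)cc1`: 15700 nM
Compound 3 `O=C(Nc1cccc(Nc2ncc(F)c(Nc3ccc(F)cc3)n2)c1)c1cnccn1`: 20100 nM

Compound 3 gives 20100 nM, the highest of the two readable numbers, though the gap to the other lies within the scatter. Within the data shown here, the only measured step of readable size is a 1.3-fold higher number from compound 2 to compound 3 (0.11 log units; within the scatter). For compound 1 there is only (the limit of > 10000 nM in this assay, at which 1 of the 3 values shown sits). The remaining measured change is a step that the limit leaves unreadable from compound 1 to compound 2, and it offers no guide.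

Compound 4 `CN1CCC(C(=O)Nc2cccc(Nc3ncc(F)c(Nc4ccc(F)cc4)n3)c2)CC1` has not yet been measured. It carries 1-methylpiperidin-4-yl in place of pyrazin-2-yl on a carbonyl carbon. Among the measured compounds shown here, the entering group brings a six-membered non-aromatic ring where the leaving group has a six-membered aromatic ring, and no measured step tests that exchange directly. In this assay compound 3 holds 20100 nM and compound 2 holds 15700 nM despite their different groups, so only a small step is expected on going to compound 4. The estimated step is a 1.3-fold lower number from compound 3 to compound 4 (0.13 log units; within the scatter). Compound 4 is expected at 15000 nM, with an estimated range of 6000 nM to 35000 nM.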

Compound 4, concentration for 50% growth inhibition: 11900 nM
Estimate against measurement, compound 4: 1.3-fold (0.10 log units) above, and the stated range covers the measured number.
By their numbers in this assay, from the lowest: compounds 4, 2 and 3 (each within the scatter of the next).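

In this assay, the exchange of a six-membered aromatic ring for a six-membered non-aromatic ring on this carbonyl carbon is now tested directly, and it gives a 1.7-fold lower number from compound 3 to compound 4 (0.23 log units; within the scatter), so at this place the change of ring type produces no readable difference. The wider exchange of the whole amide-linked group gives a 1.3-fold lower number from compound 2 to compound 4 (0.12 log units; within the scatter), which means that compound 2, compound 3 and compound 4 all stand within the scatter of one another despite carrying quite different groups. Compound 1 cannot join this comparison, as its value is a limit and not a number: the limit of > 10000 nM in this assay, at which 1 of the 4 values shown sits.

The compounds shown leave open whether the ring nitrogen of 1-methylpiperidin-4-yl counts for anything here, a question that a cyclohexyl group or an unsubstituted piperidin-4-yl on the same carbonyl carbon would address. They also leave open whether any group at this place can move the number beyond the scatter, for instance a carboxylic acid, a primary amine or a longer chain ending in a dimethylamino group.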